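This account rests on a few compounds, and the source may have more. Where it says the series, first, only, none or still open, it means among the compounds named here.

Measured so far:
compound 1, `O=C(CCl)Nc1ccc(S(=O)(=O)Oc2ccccc2I)cc1`, 4100 nM
compound 2, `O=C(CCCl)Nc1ccc(S(=O)(=O)Oc2ccccc2I)cc1`, 14000 nM

Compound 2 stands at the highest of the two numbers recorded in a functional assay on HT-29 cells (Homo sapiens) for antiproliferative activity, read by sulforhodamine B assay, with a stated time of 48 h; a lower number here means a stronger inhibitor, a higher number a weaker inhibitor. Its nearest neighbour is compound 1, and the step between them, a 3.4-fold higher number from compound 1 to compound 2 (0.53 log units; beyond the scatter), came with chloromethyl in place of chloro on a saturated chain carbon bound to a carbonyl carbon. Compound 3, `O=C(NCC1CCCC1)Nc1ccc(S(=O)(=O)Oc2ccccc2I)cc1`, has not yet been tested. It differs from compound 2 in one place: (cyclopentylmethyl)amino in place of 2-chloroethyl on a carbonyl carbon. Among the compounds with values here, the only measured step, from compound 1 to compound 2, bears on this only loosely: it shows that altering the group on the carbonyl carbon shifted this assay by a modest amount, in the direction of a higher number. Within the data shown here, the present change is far larger, and no measured pair covers the exchange of 2-chloroethyl for (cyclopentylmethyl)amino. On that thin basis a further rise is expected for compound 3, with wide uncertainty, a step of a 1.8-fold higher number from compound 2 to compound 3 (0.25 log units; within the scatter). Compound 3 is therefore estimated at 25000 nM in this assay, within a range from 6000 nM to 100000 nM.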

Compound 3, half-maximal inhibitory concentration: 7600 nM
Compound 3: middle estimate off by 3.3-fold (0.52 log units), on the high side; low and high end bracket the measured number.
By their numbers in this assay, from the lowest: compounds 1, 3 and 2 (each within the scatter of the next, the first and the last beyond it).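

The new compound shows that this carbonyl carbon can take a far bigger exchange than the earlier pair covered, without a shift beyond the scatter in this assay. Putting (cyclopentylmethyl)amino in place of 2-chloroethyl gives a 1.8-fold lower number from compound 2 to compound 3 (0.27 log units; within the scatter) and putting it in place of chloromethyl gives a 1.9-fold higher number from compound 1 to compound 3 (0.27 log units; within the scatter), so compound 3 cannot be told apart from either chlorine-bearing compound in this assay. Among these three compounds, then, the chlorine of the departing group is not needed for a number in this range, and the gap between compound 1 and compound 2 remains the only step beyond the scatter.

What the compounds shown leave open is which part of the entering group matters, the five-membered ring, the methylene link or the amide-type nitrogen with its hydrogen. An ethylamino group or a cyclohexylmethylamino group on the same carbonyl carbon would begin to separate these parts, and a 3-chloropropyl group would show whether the chloroalkyl series continues the step seen from compound 1 to compound 2. No evidence on why these numbers fall as they do accompanies the data.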